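This account rests on a few compounds, and the source may have more. Where it says the series, first, only, none or still open, it means among the compounds named here.

Working notes on the series. Compound 1 `O=[N+]([O-])c1c[nH]c(-c2nnc(-c3ccccc3)o2)c1` is the parent; in an ADME assay on Vero cells (Chlorocebus sabaeus) for cytotoxicity, read by MTT assay, with a stated time of 72 h (on this read-out lower numbers stand for stronger inhibition and higher numbers for weaker inhibition), compound 1 gives 423000 nM. Among the measured compounds shown here, of the three numbers so far it stands highest. Compound 2 `O=[N+]([O-])c1c[nH]c(-c2nnc(-c3ccccc3O)o2)c1` gives 375000 nM in this assay, and the step of a 1.1-fold lower number from compound 1 to compound 2 (0.05 log units; within the scatter) stays within the scatter. Compound 3 `N#Cc1ccc(-c2nnc(-c3cc([N+](=O)[O-])c[nH]3)o2)cc1` gives 199000 nM in this assay; the step of a 2.1-fold lower number from compound 1 to compound 3 (0.33 log units; beyond the scatter) is the only movement beyond the scatter, and it is modest.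

Compound 4 `O=[N+]([O-])c1c[nH]c(-c2nnc(-c3ccns3)o2)c1` has not yet been measured in this assay. Relative to compound 1 the change is 1,2-thiazol-5-yl in place of phenyl on an aromatic carbon. The two measured steps both keep the phenyl and only add a group to it, so neither bears directly on the loss of the phenyl itself; they show only that alterations at this position have moved the number little. On that basis a step of no more than modest size, if any, is expected from compound 1 to compound 4 in this assay, with no clear direction. The estimate for compound 4 in this assay is 380000 nM, within a range of 150000 nM to 900000 nM, meaning an expected step of a 1.1-fold lower number from compound 1 to compound 4 (0.05 log units; within the scatter).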

Compound 4, half-maximal inhibitory concentration: 532000 nM
The estimate for compound 4 lay 1.4-fold (0.15 log units) below the measured number; the measured number falls inside the stated range.
By their numbers in this assay, from the lowest: compounds 3, 2, 1 and 4 (each within the scatter of the next, the first and the last beyond it).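

In this assay, 1,2-thiazol-5-yl in place of phenyl gives a 1.3-fold higher number from compound 1 to compound 4 (0.10 log units; within the scatter), so the whole phenyl can be exchanged at this position, and not only added to, with no movement beyond the scatter. The exchange swaps a six-membered aromatic ring of carbon only for a five-membered aromatic ring with 2 hetero atoms, and brings in 2 hydrogen-bond acceptors where phenyl has 0, yet the number stays within the scatter of compound 1. No measurement at hand bears on the reason for this result.

Still open, going by these compounds, is whether a saturated ring such as piperidine, or a carboxylic acid or an amine on the phenyl, would keep the number in the same region. The compounds shown also leave open what a change to the nitro group on the shared core, such as a carboxamide in its place, would do.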